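Hexylamino in Place of Ethoxy: Expectation for Compound 3

The compounds below may be only part of what the source reports. "The series", "measured", "known", "first", "only" and "open" are said of these compounds alone.

Compound 1, `O=C(Nc1ccc2nc(NC(=O)C3CCCCC3)sc2c1)c1ccccc1Oc1ccccc1`: 0.1 ug/mL
Compound 2, `CCOC(=O)Nc1nc2ccc(NC(=O)c3c(Cl)cccc3Cl)cc2s1`: 0.0026 ug/mL

Both compounds were tested in a functional assay on WI-38 VA13 cells (Homo sapiens) for cytotoxicity; a higher number here means that more compound is needed for the effect, a lower number that less compound is needed. Compound 2 gives 0.0026 ug/mL, the lower of the two numbers; compound 1 gives 0.1 ug/mL, and the gap between them lies beyond the scatter. Compound 3, `CCCCCCNC(=O)Nc1nc2ccc(NC(=O)c3c(Cl)cccc3Cl)cc2s1`, has not yet been measured. It differs from compound 2 in one place: hexylamino in place of ethoxy on a carbonyl carbon. For the measured compounds named here, no measured pair shows this same change, so its effect cannot be read from the data at hand. The rest of compound 2 is kept, and the change sits on the carbonyl carbon whose other neighbour is an amide-type nitrogen. A small shift is expected, with the number for compound 3 somewhat higher than that of compound 2, as a 1.9-fold higher number from compound 2 to compound 3 (0.28 log units; within the scatter). Compound 3 is therefore expected to give about 0.005 ug/mL in this assay, with a range from 0.001 ug/mL to 0.03 ug/mL.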

Compound 3, half-maximal effective concentration: 0.29 ug/mL
Beside the measured number, compound 3's estimate is 58-fold (1.76 log units) below it, outside the stated range (above it).
By their numbers in this assay, from the lowest: compound 2; then compound 1; then compound 3.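

In this assay hexylamino in place of ethoxy on the carbonyl carbon gives a 110-fold higher number from compound 2 to compound 3 (2.05 log units; beyond the scatter) and shows that the number depends strongly on the group at this one place. Compounds 1 and 2 could not show this, as they differ in more than one place, whereas here the rest of compound 2 is kept and the whole step belongs to this single change. Nothing available explains the size of the step.

The change replaces the oxygen with a nitrogen that carries a hydrogen and also lengthens the chain, so the compounds shown do not separate these two differences. An ethylamino group or a hexyloxy group on the same carbonyl carbon would change only one of them and so could tell them apart.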